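The compounds below may be only part of what the source reports. "The series", "measured", "known", "first", "only" and "open" are said of these compounds alone.

Compound 1, with structure `O=S(=O)(Nc1ccc2oc(-c3ccccc3)nc2c1)c1ccc(O)cc1`, and compound 2, with structure `O=S(=O)(Nc1ccc2oc(-c3ccccc3)nc2c1)c1ccccc1O`, share the same atoms joined differently: the difference is 2-hydroxyphenyl in place of 4-hydroxyphenyl on a sulfonyl sulfur. In an assay on cells for inhibition of HSP60/HSP10 (Homo sapiens), with a stated time of 60 min (on this read-out lower numbers stand for stronger inhibition and higher numbers for weaker inhibition), compound 1 gives 88000 nM. In this assay compound 2 gives 85000 nM. The step of a 1.0-fold lower number from compound 1 to compound 2 (0.02 log units; within the scatter) shows the two lying within the usual scatter of each other.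

Compound 3, with structure `O=S(=O)(Nc1ccc2oc(-c3ccccc3)nc2c1)c1ccc(C(F)(F)F)cc1`, differs from compound 1 by trifluoromethyl in place of hydroxy on an aromatic carbon. For compound 3 the result in this assay is a limit of the assay rather than a number, > 100000 nM. The step of an at least 1.1-fold higher number from compound 1 to compound 3 (0.05 log units; that floor lies within the scatter) therefore rests on (the limit of > 100000 nM in this assay, at which 1 of the 3 values shown sits).

Compound 4, with structure `O=S(=O)(Nc1ccc2oc(-c3ccccc3)nc2c1)c1ccccc1C(F)(F)F`, has not yet been measured in this assay. It differs from compound 2 by trifluoromethyl in place of hydroxy on an aromatic carbon. Going by the values given here, this is the same kind of change as the one from compound 1 to compound 3, but not the same: there the new group sits para to a large group, here it sits ortho to a large group.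

Compound 4 is expected to give a weak result in this assay, an estimated step of a 1.8-fold higher number from compound 2 to compound 4 (0.25 log units; within the scatter), because the related change an at least 1.1-fold higher number from compound 1 to compound 3 (0.05 log units; that floor lies within the scatter) ended at the limit of > 100000 nM in this assay, at which 1 of the 3 values shown sits. The estimate for compound 4 is 150000 nM, with a range from 80000 nM to 300000 nM, and it is expected that the assay may again report only a limit.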

Compound 4, half-maximal inhibitory concentration: > 100000 nM
Compound 4: no number, only a limit (the forecaster's own chance of this, stated with the estimate: 65%); the middle value is on the limit's open side.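

In this assay compound 4 gives a limit of the assay and not a number, > 100000 nM. The step of an at least 1.1-fold higher number from compound 2 to compound 4 (0.07 log units; that floor lies within the scatter) is therefore only a floor, and trifluoromethyl in place of hydroxy has now ended at a limit on both cores, with the new group para to a large group in one case and ortho to a large group in the other; set side by side, the two steps read: the same change on two cores in this assay, an at least 1.1-fold higher number (0.05 log units; that floor lies within the scatter) from compound 1 to compound 3 and an at least 1.1-fold higher number (0.07 log units; that floor lies within the scatter) from compound 2 to compound 4; the limit leaves it open whether they differ. This shows that the change gave no measurable number on either core, but it does not show that the change has the same size on both, or that its size on either core lies beyond the scatter, since both results stop at the same ceiling of the assay: the limit of > 100000 nM in this assay, at which 2 of the 4 values shown sit.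

The compounds shown leave open how far trifluoromethyl actually weakens the result on either core, since only numbers from a more sensitive read-out could settle that. They also leave open whether a different group on this aromatic ring, such as an amine, a carboxylic acid or a methoxy group, would give a result clearly stronger than the hydroxy compounds 1 and 2.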